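The compounds below may be only part of what the source reports. "The series", "measured", "known", "first", "only" and "open" are said of these compounds alone.

In an assay on HEK293 cells for positive allosteric modulation of metabotropic glutamate receptor 3 (Rattus norvegicus), read by thallium flux, with a stated time of 2.5 min (a higher number here means that more compound is needed for the effect, a lower number that less compound is needed), compound 1 `Cc1c(OCCCCOc2cccc(C(=O)O)c2)ccc(C(=O)CC2CCCC2)c1O` gives 3400 nM, the highest number of the two given here. Its nearest neighbour, compound 2 `Cc1c(OCCCCOc2cccc(C(=O)O)c2)ccc(C(=O)CC(C)C)c1O`, gives 1430 nM, and the step from a 2.4-fold lower number from compound 1 to compound 2 (0.38 log units; beyond the scatter) was a modest one, reached by isopropyl in place of cyclopentyl on a saturated chain carbon bound to a carbonyl carbon. Compound 3 `Cc1c(OCCCCOc2cccc(C(=O)O)c2)ccc(C(=O)CC2CCCC2)c1C` shows "not determined" (no result reported) in this assay. Compound 4 `Cc1c(OCCCCOc2ccc(F)c(C(=O)O)c2)ccc(C(=O)CC2CCCC2)c1O` differs from compound 1 by fluoro in place of hydrogen on an aromatic carbon. Among the compounds with values here, no measured step touches that aromatic ring, so the one step known bears only indirectly on it, and a change within the scatter is expected in either direction. Compound 4 is therefore estimated at 3400 nM, between 1400 nM and 8000 nM, a step of no change at the digits printed from compound 1 to compound 4 (within the scatter) that is expected to stay within the scatter.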

Compound 4, half-maximal effective concentration: 2490 nM
Beside the measured number, compound 4's estimate is 1.4-fold (0.14 log units) above it, and the stated range covers the measured number.
By their numbers in this assay, from the lowest: compounds 2, 4 and 1 (each within the scatter of the next, the first and the last beyond it).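

Fluoro in place of hydrogen on the aromatic carbon ortho to a carboxy group gives a 1.4-fold lower number from compound 1 to compound 4 (0.14 log units; within the scatter). At this position, then, the added fluorine leaves the number indistinguishable from that of the parent, whereas the earlier step changed only the group on the saturated chain. Nothing available here explains this result.

As far as these compounds go, whether chloro, methoxy or an amine on this same carbon would read any differently remains open. So does whether fluoro would give the same result in the isopropyl compound 2.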